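The source may hold more compounds than are shown below. What is called first, only, known or untested is meant among the compounds shown, and "the series" means these compounds.

Measured so far:
compound 1 `O=C(Nc1ccccn1)c1c(O)c2cccnc2n(-c2ccccc2)c1=O` — -13.5%
compound 2 `O=C(NCc1cccnc1)c1c(O)c2cccnc2n(-c2ccccc2)c1=O` — 25.5%

In a functional assay on the whole organism for inhibition, with Rattus norvegicus as the target, read by paw edema, at a dose of 100 mg/kg by the oral route (a lower number here means less inhibition, a higher number more inhibition at the dose given (going by the name of the read-out)), compound 2 holds the higher of the two numbers, and compound 1 the lower. Among the compounds with values here, the single measured step, a number 39 percentage points higher from compound 1 to compound 2 (beyond the scatter), is the only guide to the series; it changed both the tether to the amide-type nitrogen and the ring attachment at once. Compound 3 `O=C(NCc1ccncc1)c1c(O)c2cccnc2n(-c2ccccc2)c1=O` keeps the methylene tether of compound 2 and differs only by pyridin-4-yl in place of pyridin-3-yl on a saturated chain carbon bound to an amide-type nitrogen. Within the data shown here, no measured pair separates a pyridin-3-yl from a pyridin-4-yl on that saturated chain carbon, so the large step seen so far does not transfer directly to this change. On that basis the expected step in this assay is small: a number 3.5 percentage points lower from compound 2 to compound 3 (within the scatter), likely within the scatter. Compound 3 is therefore estimated at 22%, with a range from -5% to 45% reflecting the thin evidence.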

Compound 3, a percentage reported as inhibition, in the whole organism at one dose (the size of the read-out at that dose, not a potency): 10%
Compound 3: middle estimate off by 12 percentage points, on the high side; low and high end bracket the measured number.
By their numbers in this assay, from the lowest: compound 1; then compound 3; then compound 2.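

In this assay, the ring attachment alone proves to matter at this position: with the methylene tether kept and the same atoms present, pyridin-4-yl in place of pyridin-3-yl on a saturated chain carbon bound to an amide-type nitrogen gives a number 15.5 percentage points lower from compound 2 to compound 3 (beyond the scatter). The (pyridin-4-yl)methyl group still stands clear of pyridin-2-yl on the amide-type nitrogen, with a number 23.5 percentage points higher from compound 1 to compound 3 (beyond the scatter), so the size of the gain over compound 1 depends on which pyridinyl group the chain carries. No evidence at hand accounts for the difference between the two pyridinyl groups.

The compounds shown do not separate the tether from the ring attachment, which (pyridin-2-yl)methyl on the same nitrogen would do. They also leave open how a longer chain, such as 2-(pyridin-3-yl)ethyl, or a plain benzyl group would fare at this dose.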